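The compounds below may be only part of what the source reports. "The series", "measured", "known", "first", "only" and "open" are said of these compounds alone.

Compound 1 `CCCCCN1CCC(NC(=O)c2cc(Cl)c(N)cc2OC)CC1`: 25.1 nM
Compound 2 `COc1cc(N)c(Cl)cc1C(=O)NC1CCN(CCCCCCCCO)CC1`: 15.9 nM
Compound 3 `COc1cc(N)c(Cl)cc1C(=O)NC1CCN(CCCCCCCCS(=O)(=O)O)CC1`: 1000 nM

In a functional assay on HEK293 cells for agonist activity at 5-hydroxytryptamine receptor 4 (Homo sapiens), read by cAMP accumulation (on this read-out higher numbers stand for an effect only at larger amounts of compound and lower numbers for an effect already at smaller amounts), compound 3 gives the highest of the three numbers: the steps run a 40-fold higher number from compound 1 to compound 3 (1.60 log units; beyond the scatter) and a 63-fold higher number from compound 2 to compound 3 (1.80 log units; beyond the scatter). Compound 4 `COc1cc(N)c(Cl)cc1C(=O)NC1CCN(CCCCCCCCN2CCCCC2)CC1` differs from compound 3 by piperidin-1-yl in place of sulfo on a saturated chain carbon, eight bonds along the chain from an amine nitrogen in a ring. The step that bears most directly on this change is a 63-fold higher number from compound 2 to compound 3 (1.80 log units; beyond the scatter), where sulfo replaced hydroxy and the number rose sharply; a 40-fold higher number from compound 1 to compound 3 (1.60 log units; beyond the scatter) points the same way. With the sulfo group leaving again, the number is expected to fall back toward those of compound 1 and compound 2, a large step in this assay toward an effect at smaller amounts, about a 50-fold lower number from compound 3 to compound 4 (1.70 log units; beyond the scatter). Compound 4 is therefore estimated at 20 nM, within a range from 5 nM to 100 nM.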

Compound 4, half-maximal effective concentration: 3.16 nM
Beside the measured number, compound 4's estimate is 6.3-fold (0.80 log units) above it; measured number below the stated range.
By their numbers in this assay, from the lowest: compound 4; then compounds 2 and 1 (each within the scatter of the next); then compound 3.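

In this assay, removing sulfo does more than restore the earlier level: a 320-fold lower number from compound 3 to compound 4 (2.50 log units; beyond the scatter), a step that carries the number past both other compounds. Piperidin-1-yl at this chain carbon also improves on hydroxy, with a 5.0-fold lower number from compound 2 to compound 4 (0.70 log units; beyond the scatter), and adding 3-(piperidin-1-yl)propyl to the shorter chain gives a 7.9-fold lower number from compound 1 to compound 4 (0.90 log units; beyond the scatter). So this chain end accepts a ring-bearing group and gains from it, rather than merely tolerating it.

Nothing available explains the gain. Going by these compounds, whether a morpholine ring, an open-chain dimethylamino group or a longer chain would do the same remains open.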